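Fluoro for hydroxy on the benzyl group of compound 1

A few compounds are considered here, and "the series" means these few. Any claim that something is new, unique, unknown or untested is made for them only; others in the source may bear on it.

Measured so far in an assay on isolated protein for inhibition of biotin--protein ligase (Homo sapiens), read by scintillation counting, with a stated time of 10 min; a lower number here means a stronger inhibitor, a higher number a weaker inhibitor:
compound 1 `O=C1N[C@H]2[C@H](CS[C@H]2CCCCCc2cn(Cc3ccccc3O)nn2)N1` gives only a limit, > 16000 nM.
compound 2 `Nc1cccc(Cn2cc(CCCCC[C@@H]3SC[C@@H]4NC(=O)N[C@@H]43)nn2)c1` gives only a limit, > 16000 nM.
compound 3 `O=C1N[C@H]2[C@H](CS[C@H]2CCCCCc2cn(Cc3ccc(C(F)(F)F)cc3)nn2)N1` gives only a limit, > 16000 nM.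

Compound 1 stands at the limit of this assay, as do the other two values; see (the limit of > 16000 nM in this assay, at which 3 of the 3 values shown sit). The steps a step that the two limits leave unreadable from compound 1 to compound 2, a step that the two limits leave unreadable from compound 1 to compound 3 and a step that the two limits leave unreadable from compound 2 to compound 3 are therefore all unreadable in size.

Compound 4 `O=C1N[C@H]2[C@H](CS[C@H]2CCCCCc2cn(Cc3ccccc3F)nn2)N1` differs from compound 1 by fluoro in place of hydroxy on an aromatic carbon. Among the compounds with values here, no measured step bears on this change in a readable way; the three related compounds all sit at the limit. For compound 4 the step that the limit leaves unreadable from compound 1 to compound 4 is expected to stay unreadable, the value most likely again a limit. Compound 4 is estimated at 20000 nM, with a range of 8000 nM to 60000 nM.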

Compound 4, inhibition constant: > 16000 nM
Compound 4 ended at the assay's limit; the forecaster's own chance of this, stated with the estimate: 85%; the middle value is on the limit's open side.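

Compound 4, like compound 1, compound 2 and compound 3, sits at a limit in this assay, so no step among them can be read in size: the limit of > 16000 nM in this assay, at which 4 of the 4 values shown sit.

The compounds shown leave open how these four benzyl groups rank against one another.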